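The source may report more compounds than this note shows. Statements on the series, on what has been measured and on what is new or still open speak of the compounds shown alone.

For the measured compounds named here, in a functional assay on MCF7 cells (Homo sapiens) for antiproliferative activity, read by MTT assay, with a stated time of 96 h (a lower number here means a stronger inhibitor, a higher number a weaker inhibitor), three compounds built on one shared core have numbers so far. Compound 1 `O=C1CC2(CCCCC2)Oc2c1ccc1ccccc21` gives 10700 nM, and compound 2 `S=C(N/N=C1\CC2(CCCCC2)Oc2c1ccc1ccccc21)N1CCNCC1` gives 14200 nM. Compound 3 `NCCCCCCC(=S)N/N=C1\CC2(CCCCC2)Oc2c1ccc1ccccc21` gives 4970 nM, the lowest of the three numbers, and its gaps to both others lie beyond the usual scatter.

Compound 4 `N/N=C1\CC2(CCCCC2)Oc2c1ccc1ccccc21` has not yet been measured. Its difference from compound 3 is a large trim on an amine nitrogen: a hydrogen atom in place of a group of 9 heavy atoms (7 carbon, 1 nitrogen, 1 sulfur; no ring), on an amine nitrogen.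

Going by the values given here, one measured step bears on this change: a 2.9-fold lower number from compound 2 to compound 3 (0.46 log units; beyond the scatter), a modest step in which 6-aminohexyl took the place of piperazin-1-yl on a thiocarbonyl carbon. Among the compounds with values here, it shows that the group at this end can shift the number, but no measured step removes the group while leaving the rest intact. Compound 1, which also lacks this chain, gives 10700 nM, so a modest rise is the likely direction.

The expected change is a 2.0-fold higher number from compound 3 to compound 4 (0.30 log units; within the scatter). For compound 4 the estimate is 10000 nM, with an expected range from 4000 nM to 25000 nM.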

Compound 4, half-maximal inhibitory concentration: 9740 nM
For compound 4 the middle estimate is 1.0-fold (0.01 log units) above the measured one; low and high end bracket the measured number.
By their numbers in this assay, from the lowest: compounds 3, 4, 1 and 2 (each within the scatter of the next, the first and the last beyond it).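

In this assay, trimming the whole group on the amine nitrogen down to a hydrogen atom gives a 2.0-fold higher number from compound 3 to compound 4 (0.29 log units; within the scatter), so this large removal cannot be told apart from no change at all. The piperazin-1-yl group tells the same story, since replacing it with hydrogen gives a 1.5-fold lower number from compound 2 to compound 4 (0.16 log units; within the scatter). Compound 4 thus sits within the scatter of both compounds, even though those two differ from each other by more than the scatter, and nothing at hand explains these numbers.

The compounds shown leave open whether a chain shorter or longer than 6-aminohexyl on the thiocarbonyl carbon would separate clearly from compound 4. They also leave open what a carbonyl in place of the thiocarbonyl, or a morpholine ring in place of the piperazine, would do.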